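The source may hold more compounds than are shown below. What is called first, only, known or untested is meant among the compounds shown, and "the series" means these compounds.

Compound 2 `Nc1cccc(Cn2cc(CCCCC[C@@H]3SC[C@@H]4NC(=O)N[C@@H]43)nn2)c1` is the starting point. In an assay on isolated protein for inhibition of biotin--protein ligase (Homo sapiens), read by scintillation counting, with a stated time of 10 min (a higher number here means a weaker inhibitor, a lower number a stronger inhibitor), compound 2 gives > 16000 nM, and this is a limit of the assay rather than a measured number. Two neighbours share its core and differ only on the aromatic carbon that carries the amino group. Compound 1 `O=C1N[C@H]2[C@H](CS[C@H]2CCCCCc2cn(Cc3cccc(O)c3)nn2)N1` has a hydroxy there; in this assay compound 1 gives > 16000 nM, again a limit. Compound 3 `O=C1N[C@H]2[C@H](CS[C@H]2CCCCCc2cn(Cc3cccc(F)c3)nn2)N1` has a fluorine there; in this assay compound 3 gives > 16000 nM, also a limit. Because all three sit at the limit of > 16000 nM in this assay, at which 3 of the 3 values shown sit, the steps a step that the two limits leave unreadable from compound 1 to compound 2, a step that the two limits leave unreadable from compound 1 to compound 3 and a step that the two limits leave unreadable from compound 2 to compound 3 cannot be read in size or direction; each only shows that swapping hydroxy, amino or fluoro on that aromatic carbon did not bring any compound within reach of the assay.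

Compound 4 `O=C1N[C@H]2[C@H](CS[C@H]2CCCCCc2cn(Cc3ccc(F)cc3)nn2)N1` has not yet been measured. It differs from compound 2 by 4-fluorophenyl in place of 3-aminophenyl on a saturated chain carbon bound to an aromatic nitrogen, so the hydrogen-bond donor and acceptor of the amino group are lost and a fluorine enters the ring at another place. Within the data shown here, the measured steps bear on it only in that every variation of this benzyl ring so far stayed at the limit, with no step readable. The step that the limit leaves unreadable from compound 2 to compound 4 is therefore expected to be unreadable again. Compound 4 is expected to give 30000 nM, with a range from 10000 nM to 120000 nM, most probably reported once more only as a limit.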

Compound 4, inhibition constant: > 16000 nM
Compound 4: a limit, no number (the forecaster's own chance of this, stated with the estimate: 85%); the middle value lies beyond the limit too.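

Compound 4 also gives only a limit in this assay, so the steps linking it to compound 1, compound 2 and compound 3 cannot be read in size or direction: the limit of > 16000 nM in this assay, at which 4 of the 4 values shown sit. The compounds shown leave open how strong an inhibitor each of the four is, and whether any change on this benzyl ring alters that strength.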